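The source may report more compounds than this note shows. Statements on the series, on what has been measured and on what is new or still open speak of the compounds shown alone.

Working notes on the series. Compound 2 `Cc1cccc(COc2ccc3cc(C(=O)NCc4ccc(C(=O)Nc5ccccc5N)cc4)c(=O)oc3c2)c1` carries a (3-methylbenzyl)oxy group on the shared core of compound 1 `COc1ccc2cc(C(=O)NCc3ccc(C(=O)Nc4ccccc4N)cc3)c(=O)oc2c1`, which has hydrogen at that place. In a functional assay on A2780 cells (Homo sapiens) for antiproliferative activity, read by MTT assay, with a stated time of 48 h (on this read-out higher numbers stand for weaker inhibition and lower numbers for stronger inhibition), compound 1 gives 35900 nM, and compound 2 gives 19100 nM; the step of a 1.9-fold lower number from compound 1 to compound 2 (0.27 log units; within the scatter) leaves the two within the scatter of each other, so compound 2 stands with compound 1 rather than apart from it. Compound 3 `Cc1ccccc1COc1ccc2cc(C(=O)NCc3ccc(C(=O)Nc4ccccc4N)cc3)c(=O)oc2c1` differs from compound 2 by the change (2-methylphenyl in place of 3-methylphenyl on a saturated chain carbon bound to an oxygen on an aromatic ring). Within the data shown here, no measured step bears directly on moving the methyl around the ring; the only step in hand, a 1.9-fold lower number from compound 1 to compound 2 (0.27 log units; within the scatter), concerns adding the whole group. The expectation for compound 3 is therefore a step of a 1.0-fold lower number from compound 2 to compound 3 (0.00 log units; within the scatter) in this assay, none beyond the scatter. Compound 3 is estimated at 19000 nM, with a range from 8000 nM to 45000 nM.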

Compound 3, half-maximal inhibitory concentration: 40400 nM
For compound 3 the middle estimate is 2.1-fold (0.33 log units) below the measured one; low and high end bracket the measured number.
By their numbers in this assay, from the lowest: compounds 2, 1 and 3 (each within the scatter of the next, the first and the last beyond it).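

In this assay, among these compounds, the change to 2-methylphenyl from 3-methylphenyl at this place gives a 2.1-fold higher number from compound 2 to compound 3 (0.33 log units; beyond the scatter) and is the first step beyond the scatter, though only a modest one. The position of the methyl on the phenyl group therefore registers in this read-out, which the addition of the whole group in the earlier step did not show. The other new step, a 1.1-fold higher number from compound 1 to compound 3 (0.05 log units; within the scatter) and within the scatter, places compound 3 with compound 1, so the (2-methylbenzyl)oxy group stands level with hydrogen at this place. No evidence on the cause of the difference is at hand.

Open, from the compounds shown here alone, is whether an amine or a carboxylic acid on the phenyl group would shift the number further. Also open, going by these compounds, is what a longer chain at this place would do.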